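The compounds below may be only part of what the source reports. "The series", "measured", "known", "first", "only" and "open" are said of these compounds alone.

Measured compounds:
Compound 1, `COc1ccccc1CC(Oc1ccc(C(C)C)cc1)C(=O)O`, gives a limit in a functional assay on the whole organism for inhibition, with Rattus norvegicus as the target (a higher number here means that more compound is needed for the effect, a lower number that less compound is needed), > 10 mg/kg.
Compound 2, `CC(C)c1ccc(OC(C)(Cc2cccc(Cl)c2)C(=O)O)cc1`, gives 5 mg/kg in this assay.
Compound 3, `CCCc1cccc(CC(C)(Oc2ccc(C(C)C)cc2)C(=O)O)c1`, gives 1 mg/kg in this assay.

Compound 2 stands at the highest of the two numbers in this assay; the nearest number is that of compound 3, reached by a 5.0-fold lower number from compound 2 to compound 3 (0.70 log units; beyond the scatter), where a propyl group takes the place of the chloro group. Compound 1 carries a limit rather than a number, (the limit of > 10 mg/kg in this assay, at which 1 of the 3 values shown sits).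

Compound 4, `COc1ccc(CC(C)(Oc2ccc(C(C)C)cc2)C(=O)O)cc1`, has not been measured. It differs from compound 2 in one place: 4-methoxyphenyl in place of 3-chlorophenyl on a saturated chain carbon, two bonds along the chain from a carbonyl carbon and an oxygen on an aromatic ring. For the measured compounds named here, the only measured step that touches the same ring is the one from compound 2 to compound 3, a modest one beyond the scatter, but it exchanges chloro for propyl, not for methoxy, and it changes the group at a different position of that ring. Compound 1, which also bears a methoxy-substituted ring, gives only a limit. The two pieces of evidence pull in opposite directions, so the expected step is small.

The estimate for compound 4 in this assay is 7 mg/kg, with a range from 2 mg/kg to 20 mg/kg. This estimate means a step of a 1.4-fold higher number from compound 2 to compound 4 (0.15 log units; within the scatter), expected to lie within the scatter.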

Compound 4, dose for half-maximal effect: > 10 mg/kg
Compound 4: only a limit was reported; the forecaster's own chance of this, stated with the estimate: 35%; at least 1.4-fold (0.15 log units) between middle value and limit.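

At this place on the saturated chain carbon, the 4-methoxyphenyl group yields no number: compound 4 carries only a limit in this assay, > 10 mg/kg. As far as these compounds go, putting 4-methoxyphenyl in place of 3-chlorophenyl gives an at least 2.0-fold higher number from compound 2 to compound 4 (0.30 log units; that floor lies within the scatter), so this change brings no visible gain, while a true loss is not established and the real size of the step remains unknown. The earlier step, a 5.0-fold lower number from compound 2 to compound 3 (0.70 log units; beyond the scatter), showed that changing the group on this ring can lower the number; the new result shows that a change here need not do so, and the limit now accounts for more of the series: the limit of > 10 mg/kg in this assay, at which 2 of the 4 values shown sit.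

The step to compound 4 changes both the group on the ring and where it sits, so the two effects cannot be separated; a 3-methoxyphenyl or a 4-chlorophenyl group at the same chain carbon would be needed to tell them apart. From the compounds shown here alone, it also remains open whether a chain longer than propyl, such as butyl, on the ring of compound 3 would lower the number further.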